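The compounds below may be only part of what the source reports. "The series", "measured", "known", "first", "only" and "open" are said of these compounds alone.

Measured compounds:
- compound 1, `N=C(NCCCc1c[nH]cn1)NCCC(c1ccc(F)cc1)c1ccccn1`: 7.94
- compound 2, `N=C(NCCCc1c[nH]cn1)NCCC(c1ccc(Br)cc1)c1ccccn1`: 6.97

Both were tested in a functional assay on muscle tissue for agonist activity at histamine H2 receptor (Cavia porcellus); on this read-out higher numbers stand for higher potency (the scale is a negative logarithm) and lower numbers for lower potency. Compound 1 and compound 2 share one core and differ only in the halogen on the phenyl ring. Of the two numbers, compound 2 stands lowest, and its nearest neighbour is compound 1, which lies a number 0.97 log units lower from compound 1 to compound 2 (beyond the scatter) higher. The step from fluoro to bromo therefore shows that this phenyl ring matters, and that a change there can move the number beyond the usual scatter.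

The next compound, compound 3, is `N=C(NCCCc1c[nH]cn1)NCCC(c1cccc(C(F)(F)F)c1)c1ccccn1`. It differs from compound 2 in one place: 3-(trifluoromethyl)phenyl in place of 4-bromophenyl on a saturated chain carbon bound to an aromatic carbon and a saturated chain carbon. For the measured compounds named here, only one measured step bears on this change, the one from compound 1 to compound 2, which was a number 0.97 log units lower from compound 1 to compound 2 (beyond the scatter) and moderate. A trifluoromethyl group at the 3-position has no direct comparison among the measured compounds, so the direction is uncertain; the step is expected to be modest and to stay within roughly the span already seen. Compound 3 is therefore estimated at 7.3 in this assay, with a range from 6.6 to 8, which would mean a step of a number 0.33 log units higher from compound 2 to compound 3 (beyond the scatter).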

Compound 3, negative logarithm of the half-maximal effective concentration: 7.44
Estimate against measurement, compound 3: 0.14 log units below; the measured number falls inside the stated range.
By their numbers in this assay, from the lowest: compound 2; then compound 3; then compound 1.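

On this assay the 3-(trifluoromethyl)phenyl group gives a number 0.47 log units higher from compound 2 to compound 3 (beyond the scatter) when it replaces 4-bromophenyl, and a number 0.50 log units lower from compound 1 to compound 3 (beyond the scatter) when it replaces 4-fluorophenyl. The new group therefore places compound 3 between the two halogen compounds, so this position on the saturated chain carbon supports more than two levels of potency, and the entering group's 10 heavy atoms, against 7 in 4-bromophenyl, did not bring a lower number in this pair. Nothing among the data shown explains why the number moves in this way.

Each of these steps changes both the substituent and where it sits on the phenyl ring, so the compounds shown cannot separate the effect of swapping the substituent from the effect of moving it. They also leave open how a phenyl ring carrying a nitrile, a methoxy group or an amine would behave, and whether any such group could reach or pass the number of compound 1 at 7.94 on this read-out.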